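The source may report more compounds than this note shows. Statements on the series, on what has been measured and on what is new or still open speak of the compounds shown alone.

Compound 1 `COc1ncnc2c1c(-c1ccsc1)cn2[C@@H]1O[C@H](CO)[C@@H](O)[C@H]1O` gives 130 nM; compound 3 `C#Cc1cn([C@@H]2O[C@H](CO)[C@@H](O)[C@H]2O)c2ncnc(OC)c12` gives 190 nM; compound 2 `Cc1ncnc2c1c(-c1cc3ccccc3o1)cn2[C@@H]1O[C@H](CO)[C@@H](O)[C@H]1O` reaches only a limit of the assay in a functional assay on HL-60 cells (Homo sapiens) for antiproliferative activity, read by XTT assay, with a stated time of 72 h (a lower number here means a stronger inhibitor, a higher number a weaker inhibitor), namely > 20000 nM.

Compound 3 has the higher of the two numbers, and its nearest neighbour is compound 1, which lies within the scatter: a 1.5-fold higher number from compound 1 to compound 3 (0.16 log units; within the scatter). Compound 4 `COc1ncnc2c1c(-c1cc3ccccc3o1)cn2[C@@H]1O[C@H](CO)[C@@H](O)[C@H]1O` differs from compound 3 in one place: 1-benzofuran-2-yl in place of ethynyl on an aromatic carbon. For the measured compounds named here, the only measured step that bears on this change is the exchange at the same aromatic carbon between compound 1 and compound 3, which lies within the scatter. Compound 2 carries the same 1-benzofuran-2-yl group but differs elsewhere as well, so it shows only a limit (the limit of > 20000 nM in this assay, at which 1 of the 3 values shown sits). A weaker value is expected for compound 4, estimated at 1000 nM, within 150 nM to 10000 nM, meaning the step of a 5.3-fold higher number from compound 3 to compound 4 (0.72 log units; beyond the scatter).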

Compound 4, half-maximal inhibitory concentration: 4470 nM
Compound 4: the middle estimate sits 4.5-fold (0.65 log units) below what was measured, within the range that was stated.
By their numbers in this assay, from the lowest: compounds 1 and 3 (each within the scatter of the next); then compound 4. At a limit, above all of these: compound 2.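

In this assay, this aromatic carbon no longer appears indifferent to its group: thiophen-3-yl and ethynyl stayed within the scatter of each other, but 1-benzofuran-2-yl gives a 24-fold higher number from compound 3 to compound 4 (1.37 log units; beyond the scatter) and a 34-fold higher number from compound 1 to compound 4 (1.54 log units; beyond the scatter). With 1-benzofuran-2-yl held constant, methoxy in place of methyl also counts, giving an at least 4.4-fold lower number from compound 2 to compound 4 (0.65 log units; beyond the scatter). Compound 2 marks a limit, not a number: the limit of > 20000 nM in this assay, at which 1 of the 4 values shown sits.

The compounds shown leave open how a furan-2-yl or a phenyl group would fare at this carbon. The data do not separate the fused six-membered ring from the rest of the 1-benzofuran-2-yl group.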